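A few compounds are considered here, and "the series" means these few. Any claim that something is new, unique, unknown or untested is made for them only; others in the source may bear on it.

Measured so far:
compound 1 `COc1cc(/C=N/NC(=O)CCc2nc3ccccc3c(=O)[nH]2)cc(OC)c1OC` — in a physicochemical assay, read by spectrophotometry, with a stated time of 15 min (a lower number here means a stronger inhibitor, a higher number a weaker inhibitor), compound 1 gives 80000000 nM
compound 2 `COc1cc(/C=N/NC(=O)CCc2nc3ccccc3c(=O)[nH]2)ccc1O` — in this assay compound 2 gives 290000000 nM
compound 3 `COc1cc(/C=N/NC(=O)CCCc2nc3ccccc3c(=O)[nH]2)cc(OC)c1OC` — in this assay compound 3 gives 85000000 nM

Compound 2 stands at the highest number of the three, that is, as the weakest inhibitor in this set. Its nearest neighbour is compound 3, whose number lies lower by more than the usual scatter; compound 1 lies further off, also lower and also beyond the scatter. Going by the values given here, no two measured compounds differ in one place only, so no single structural step can be read off from these three numbers.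

Compound 4 `COc1cc(/C=N/NC(=O)CCc2nc3ccccc3c(=O)[nH]2)cc(O)c1O` differs from compound 2 in one place: hydroxy in place of hydrogen on an aromatic carbon. The entering hydroxy sits ortho to the hydroxy group already present and meta to the methoxy group.

Among the compounds with values here, nothing among the measured compounds tests this change, so the expectation rests on the change alone. In this assay the step is expected to be a 4.1-fold lower number from compound 2 to compound 4 (0.62 log units; beyond the scatter). In this assay compound 4 is therefore estimated at 70000000 nM, with a range from 25000000 nM to 200000000 nM.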

Compound 4, half-maximal inhibitory concentration: 50000000 nM
Compound 4: the middle estimate sits 1.4-fold (0.15 log units) above what was measured, within the range that was stated.
By their numbers in this assay, from the lowest: compounds 4, 1 and 3 (each within the scatter of the next); then compound 2.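

In this assay, going by these compounds alone, this is the first change that can be read in one place: hydroxy in place of hydrogen on an aromatic carbon, ortho to a hydroxy group and meta to a methoxy group, gives a 5.8-fold lower number from compound 2 to compound 4 (0.76 log units; beyond the scatter). The step lies beyond the scatter, so this aromatic carbon is a position where a substituent registers in the number, and the entering hydroxy moves it in the direction of a stronger inhibitor, although this rests on a single pair of compounds. Nothing measured here explains the step.

The compounds shown leave open whether the step belongs to hydroxy specifically, as no pair places an amine or a carboxylic acid on this same aromatic carbon for comparison. Within the data shown here, also open is whether the same hydroxy step would hold with the longer chain carried by compound 3, as no pair that differs in one place tests the change on that chain.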